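Halogen swap on the phenoxy ring, carried to the ethoxy core

The compounds below may be only part of what the source reports. "The series", "measured", "known", "first", "only" and "open" are said of these compounds alone.

Compound 1 `Clc1ccc(Cc2nnc(SCc3ccccc3)[nH]2)c(Oc2ccccc2Cl)c1` gives 129% in a functional assay on the whole organism (strain NMRI) with Mus musculus as the target, with a stated time of 60 min, at a dose of 20 mg/kg by the intraperitoneal route; on this read-out higher numbers stand for a stronger effect at the one dose given and lower numbers for a weaker effect. Compound 2 `Fc1ccccc1Oc1cc(Cl)ccc1Cc1nnc(SCc2ccccc2)[nH]1` differs from compound 1 by fluoro in place of chloro on an aromatic carbon and in this assay compound 2 gives 179%, a step of a number 50 percentage points higher from compound 1 to compound 2 (beyond the scatter). Compound 3 `CCOc1nnc(Cc2ccc(Cl)cc2Oc2ccccc2Cl)[nH]1` carries a different core, the difference from compound 1 being (ethoxy in place of benzylsulfanyl on an aromatic carbon); in this assay compound 3 gives 135%, which is a number 6 percentage points higher from compound 1 to compound 3 (within the scatter), so the two cores sit close together on this read-out.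

Compound 4 `CCOc1nnc(Cc2ccc(Cl)cc2Oc2ccccc2F)[nH]1` is not yet measured. It stands to compound 3 as compound 2 stands to compound 1: the difference is fluoro in place of chloro on an aromatic carbon, with the place described in the same words as before, so it is the same change on the other core. Since the two cores gave nearly the same number in compound 1 and compound 3, the step from compound 3 to compound 4 is expected to resemble the one seen earlier, put at a number 40 percentage points higher from compound 3 to compound 4 (beyond the scatter) and taken a little smaller than a number 50 percentage points higher from compound 1 to compound 2 (beyond the scatter) because that one rests on a single pair. For compound 4 the estimate in this assay is 175%, within 140% to 215%.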

Compound 4, a percentage reported as activity, at one dose (the size of the read-out at that dose, not a potency): 138%
The estimate for compound 4 lay 37 percentage points above the measured number; measured number outside the range, below it.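

In this assay, 2-fluorophenoxy in place of 2-chlorophenoxy on the ethoxy core gives a number 3 percentage points higher from compound 3 to compound 4 (within the scatter), so the gain seen with the benzylsulfanyl group does not carry over to this core: the same change on two cores in this assay, a number 50 percentage points higher (beyond the scatter) from compound 1 to compound 2 and a number 3 percentage points higher (within the scatter) from compound 3 to compound 4, 47 percentage points apart, beyond the scatter of two such steps. Read the other way, ethoxy in place of benzylsulfanyl gives a number 41 percentage points lower from compound 2 to compound 4 (beyond the scatter) with the 2-fluorophenoxy group, whereas the same change with the 2-chlorophenoxy group stayed within the scatter: the same change on two cores in this assay, a number 6 percentage points higher (within the scatter) from compound 1 to compound 3 and a number 41 percentage points lower (beyond the scatter) from compound 2 to compound 4, 47 percentage points apart, beyond the scatter of two such steps. The two changes therefore do not add up independently in these four compounds, with compound 2 alone standing apart, but a single pair on each core gives no cause for this and no rule for other cores.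

The compounds shown leave open whether the gain needs the benzylsulfanyl group itself or would also appear with a methylsulfanyl group or a longer alkoxy chain in that place. They also leave open how an amine there would respond to the halogen swap, and whether a bromo group or an unsubstituted phenoxy ring would follow compound 2 or compound 4.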